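Swapping the Ester for a Methyltetrazole at One Position

The source may hold more compounds than are shown below. What is called first, only, known or untested is meant among the compounds shown, and "the series" means these compounds.

In an assay on isolated protein with Polyunsaturated fatty acid 5-lipoxygenase (Homo sapiens) as the target (on this read-out lower numbers stand for stronger inhibition and higher numbers for weaker inhibition), compound 3 `COC(=O)c1cc(-c2ccccc2)c2ccc(OCc3cccc(C4(O)CCOCC4)c3)cc2c1` gives 70 nM, the lowest of the three numbers measured. Compound 2 `CC(=O)c1cc(-c2ccccc2)c2ccc(OCc3cccc(C4(O)CCOCC4)c3)cc2c1` gives 130 nM, and the step of a 1.9-fold lower number from compound 2 to compound 3 (0.27 log units; within the scatter) lies within the scatter, so these two cannot be ordered. Compound 1 `CC(C)(O)c1cc(-c2ccccc2)c2ccc(OCc3cccc(C4(O)CCOCC4)c3)cc2c1` gives 1500 nM, and the steps of a 12-fold lower number from compound 1 to compound 2 (1.06 log units; beyond the scatter) and a 21-fold lower number from compound 1 to compound 3 (1.33 log units; beyond the scatter) were both large. Compound 4 `Cn1nnnc1-c1cc(-c2ccccc2)c2ccc(OCc3cccc(C4(O)CCOCC4)c3)cc2c1` differs from compound 3 by 1-methyl-1H-tetrazol-5-yl in place of methoxycarbonyl on an aromatic carbon. Within the data shown here, the measured steps show that acetyl and methoxycarbonyl are both well tolerated here, while 1-hydroxy-1-methylethyl is much worse; no measured step covers an aromatic group at this place. The expected change is therefore a 2.1-fold higher number from compound 3 to compound 4 (0.33 log units; beyond the scatter), a modest loss at most. Compound 4 is estimated at 150 nM in this assay, between 40 nM and 600 nM.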

Compound 4, half-maximal inhibitory concentration: 3000 nM
Estimate against measurement, compound 4: 20-fold (1.30 log units) below; measured number above the stated range.
By their numbers in this assay, from the lowest: compounds 3 and 2 (each within the scatter of the next); then compounds 1 and 4 (each within the scatter of the next).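

With the 1-methyl-1H-tetrazol-5-yl group on this aromatic carbon, the position proves far less permissive than acetyl and methoxycarbonyl suggested, with a 43-fold higher number from compound 3 to compound 4 (1.63 log units; beyond the scatter) and a 23-fold higher number from compound 2 to compound 4 (1.36 log units; beyond the scatter) both large. Against 1-hydroxy-1-methylethyl, a 2.0-fold higher number from compound 1 to compound 4 (0.30 log units; within the scatter) leaves the two groups unordered, so this first aromatic ring at the position sits at the poor end of the series rather than with the two carbonyl groups. Nothing available explains this loss. Still open, going by these compounds, is how a carboxylic acid, a primary amide or an unmethylated tetrazole would fare at this position on the same core.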